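A few compounds are considered here, and "the series" means these few. Any claim that something is new, unique, unknown or untested is made for them only; others in the source may bear on it.

- Compound 1 `Oc1cc(-c2ccc(Cl)cc2)nc2ncccc12` in a functional assay on OVCAR-3 cells (Homo sapiens) (a lower number here means a stronger inhibitor of growth, a higher number a weaker inhibitor of growth), gives 23400 nM
- Compound 2 `Cc1cnc2nc(-c3ccc(Cl)cc3)cc(O)c2c1` in this assay gives 2240 nM

Compound 2 holds the lower of these two numbers. Compound 3 `Cc1cnc2nc(-c3ccc(F)cc3)cc(O)c2c1` differs from it by fluoro in place of chloro on an aromatic carbon. Within the data shown here, the only measured step (a 10-fold lower number from compound 1 to compound 2 (1.02 log units; beyond the scatter)) was large, but it is methyl in place of hydrogen on an aromatic carbon, and no measured step tests the new change. No shift beyond the scatter is therefore expected, and the estimated step is small (a 1.3-fold higher number from compound 2 to compound 3 (0.13 log units; within the scatter)). Compound 3 is estimated at 3000 nM with an expected range from 900 nM to 9000 nM.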

Compound 3, concentration for 50% growth inhibition: 22400 nM
Compound 3: middle estimate off by 7.5-fold (0.87 log units), on the low side, and the stated range ends below it.
By their numbers in this assay, from the lowest: compound 2; then compounds 3 and 1 (each within the scatter of the next).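

In this assay, the halogen on the aromatic carbon para to a large group proves far from interchangeable: fluoro in place of chloro gives a 10-fold higher number from compound 2 to compound 3 (1.00 log units; beyond the scatter) with the methyl present. A change of one heavy atom at this position thus moves the number by a step beyond the scatter, and here chloro holds the lower number. Nothing available explains why these two halogens differ. On these data alone, whether bromo or methoxy in this place would match chloro remains open, as does whether chloro keeps its advantage over fluoro on the core without the methyl.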